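The source may hold more compounds than are shown below. What is called first, only, known or untested is meant among the compounds shown, and "the series" means these compounds.

Measured so far:
compound 1 `COc1ccc(/C=C/C2(C)C=CC(=O)O2)c(OC)c1OC`, 90000 nM; compound 2 `COc1c(O)ccc(/C=C/C2(C)C=CC(=O)O2)c1OC`, 131000 nM; compound 3 `CC1(/C=C/c2ccccc2O)C=CC(=O)O1`, 112000 nM.

Three lactones were tested in a functional assay on PC-3 cells (Homo sapiens) for inhibition, read by sulforhodamine B assay, with a stated time of 48 h; on this read-out higher numbers stand for weaker inhibition of growth and lower numbers for stronger inhibition of growth. Compound 1 `COc1ccc(/C=C/C2(C)C=CC(=O)O2)c(OC)c1OC` gives 90000 nM. Compound 2 `COc1c(O)ccc(/C=C/C2(C)C=CC(=O)O2)c1OC` gives 131000 nM. Compound 3 `CC1(/C=C/c2ccccc2O)C=CC(=O)O1` gives 112000 nM. All three values lie within the usual scatter of one another, so no order among them is claimed.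

Within the data shown here, the one change that can be followed is methyl in place of hydrogen on an oxygen on an aromatic ring, and it gives a 1.5-fold lower number from compound 2 to compound 1 (0.16 log units; within the scatter). The difference between the cores of compound 2 and compound 3 is not broken down here.

Compound 4 `COc1ccccc1/C=C/C1(C)C=CC(=O)O1` has not yet been measured. It differs from compound 3 by methyl in place of hydrogen on an oxygen on an aromatic ring, the same kind of change as from compound 2 to compound 1, with the same place described around it. Among the measured compounds shown here, the step is expected to be small, a 1.3-fold lower number from compound 3 to compound 4 (0.12 log units; within the scatter), because the only measured instance of this change gave a 1.5-fold lower number from compound 2 to compound 1 (0.16 log units; within the scatter). On that basis compound 4 is estimated at 85000 nM in this assay, with the range 45000 nM to 160000 nM.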

Compound 4, concentration for total growth inhibition: 34200 nM
The estimate for compound 4 lay 2.5-fold (0.40 log units) above the measured number; measured number outside the range, below it.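

In this assay, methyl in place of hydrogen on an oxygen on an aromatic ring gives a 3.3-fold lower number from compound 3 to compound 4 (0.52 log units; beyond the scatter), and this step, unlike the earlier one, is printed as beyond the usual scatter. Even so, the two steps do not differ by more than two such steps can scatter, so the change can be carried from one core to the other without any detectable difference in its size: the same change on two cores in this assay, a 1.5-fold lower number (0.16 log units; within the scatter) from compound 2 to compound 1 and a 3.3-fold lower number (0.52 log units; beyond the scatter) from compound 3 to compound 4, 2.2-fold (0.35 log units) apart, within the scatter of two such steps. This rests on only two instances, one of them within the scatter, so it does not establish a constant step across the series, nor does it show that the change lowers the number on every core.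

The compounds shown leave open what a longer chain on that oxygen, such as ethyl, would do in place of methyl. They also leave open how an amine would read in place of the hydroxy group on the same ring.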